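From 3,4-difluorophenyl to pyridin-3-yl on the amide

The source may report more compounds than this note shows. Statements on the series, on what has been measured and on what is new or still open speak of the compounds shown alone.

In an in vitro ADME assay on microsomes from liver (Mus musculus) for pharmacokinetics, read by LC-MS, with a stated time of 10 min, tested at 1 uM (on this read-out lower numbers stand for slow clearance and higher numbers for fast clearance), compound 1 `Cc1ccc(NC(=O)[C@H]2CN(C)C[C@@H]2c2ccc(/C=C/C(=O)Nc3ccccc3N)cc2)cc1` gives 62 mL/min/kg. Going by the values given here, compound 2 `CN1C[C@H](C(=O)Nc2ccc(F)c(F)c2)[C@@H](c2ccc(/C=C/C(=O)Nc3ccccc3N)cc2)C1` gives 46 mL/min/kg, which lies within the usual scatter of the only other measured number, so the two compounds cannot be told apart here. Compound 3 `CN1C[C@H](C(=O)Nc2cccnc2)[C@@H](c2ccc(/C=C/C(=O)Nc3ccccc3N)cc2)C1` has not yet been measured. It keeps the shared core of compound 2 and changes one group: pyridin-3-yl in place of 3,4-difluorophenyl on an amide-type nitrogen, (pyridin-3-yl in place of 3,4-difluorophenyl on an amide-type nitrogen).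

Among the compounds with values here, only one measured step bears on this change, and it sits on the same amide-type nitrogen: a 1.3-fold lower number from compound 1 to compound 2 (0.13 log units; within the scatter). That step is small, but it exchanges one aromatic ring of carbon only for another. Within the data shown here, no measured compound carries a ring with a hetero atom, so the data offer no direction for this swap. The expected outcome is therefore no shift beyond the scatter, with a wide margin: a 1.1-fold lower number from compound 2 to compound 3 (0.04 log units; within the scatter). In this assay the estimate for compound 3 is 42 mL/min/kg, with an expected range from 22 mL/min/kg to 78 mL/min/kg.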

Compound 3, clearance: 41 mL/min/kg
For compound 3 the middle estimate is 1.0-fold (0.01 log units) above the measured one; measured number inside the range.
By their numbers in this assay, from the lowest: compounds 3, 2 and 1 (each within the scatter of the next).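

With a nitrogen now in the ring, this position has its first aromatic ring that is not carbon only, and this assay still shows no shift that stands out: pyridin-3-yl in place of 3,4-difluorophenyl gives a 1.1-fold lower number from compound 2 to compound 3 (0.05 log units; within the scatter), and pyridin-3-yl in place of 4-methylphenyl gives a 1.5-fold lower number from compound 1 to compound 3 (0.18 log units; within the scatter). Going by these compounds alone, the earlier pair compared only two rings of carbon, whereas these steps show that neither the loss of both fluorines nor the arrival of a ring nitrogen, which adds a hydrogen-bond acceptor, moves the number beyond the usual scatter, so the three compounds cannot be told apart at this amide-type nitrogen. Nothing given here explains why the number holds across these rings.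

From the compounds shown here alone, all three compounds carry a six-membered aromatic ring on this nitrogen, so it remains open whether a saturated group such as cyclohexyl, or a ring bearing a carboxylic acid or an amine, would give a number outside the scatter. Going by these compounds, it is also open whether the ring nitrogen matters in another placement, as in pyridin-2-yl or pyridin-4-yl.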